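Alkynyl alcohol swap from compound 3 to compound 4

The source may hold more compounds than are shown below. What is called first, only, known or untested is meant among the compounds shown, and "the series" means these compounds.

compound 1 `Nc1ccc(S(=O)(=O)N2CCN(c3ncc(C(O)(C(F)(F)F)C(F)(F)F)cc3Br)CC2)cn1`: < 14 mL.min-1.g-1 (a limit)
compound 2 `Nc1ccc(S(=O)(=O)N2CCN(c3ncc(C(O)(C(F)(F)F)C(F)(F)F)cc3C3CC3)CC2)cn1`: 38 mL.min-1.g-1
compound 3 `CC(C)(O)C#Cc1cc(C(O)(C(F)(F)F)C(F)(F)F)cnc1N1CCN(S(=O)(=O)c2ccc(N)nc2)CC1`: < 14 mL.min-1.g-1 (a limit)

In an ADME assay (liver) for metabolic stability, with Liver microsome (Homo sapiens) as the target, using microsomes and NADPH, with a stated time of 30 min, tested at 1 uM (on this read-out lower numbers stand for slow clearance and higher numbers for fast clearance), compound 3 gives < 14 mL.min-1.g-1, which is a limit and not a number. It therefore stands at the limit of < 14 mL.min-1.g-1 in this assay, at which 2 of the 3 values shown sit, and only compound 2 gives a number.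

Compound 4 `Nc1ccc(S(=O)(=O)N2CCN(c3ncc(C(O)(C(F)(F)F)C(F)(F)F)cc3C#CCCO)CC2)cn1` differs from it in one place: 2-hydroxyethyl in place of 1-hydroxy-1-methylethyl on a triple-bonded carbon. The group changes from 3-hydroxy-3-methylbut-1-yn-1-yl to 4-hydroxybut-1-yn-1-yl.

Among the compounds with values here, no measured step changes this chain end. The nearest steps replace the whole group on the aromatic carbon: an at least 2.7-fold higher number from compound 1 to compound 2 (0.43 log units; beyond the scatter), then an at least 2.7-fold lower number from compound 2 to compound 3 (0.43 log units; beyond the scatter), while a step that the two limits leave unreadable from compound 1 to compound 3 gives no size. The readable steps swap cyclopropyl for bromo or for the alkynyl alcohol, a larger change than this one, so no step beyond the scatter is expected in this assay.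

The step expected is a step that the limit leaves unreadable from compound 3 to compound 4.

The estimate for compound 4 is 12 mL.min-1.g-1, with an expected range from 7 mL.min-1.g-1 to 26 mL.min-1.g-1.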

Compound 4, intrinsic clearance in microsomes: < 14 mL.min-1.g-1
Compound 4: a limit, no number; the forecaster's own chance of this, stated with the estimate: 60%; the middle value does not contradict the limit.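

In this assay compound 4 gives < 14 mL.min-1.g-1, which is a limit and not a number. With cyclopropyl replaced by 4-hydroxybut-1-yn-1-yl, the result is an at least 2.7-fold lower number from compound 2 to compound 4 (0.43 log units; beyond the scatter), so the low reading seen for compound 3 does not require the 1-hydroxy-1-methylethyl end and also holds with 2-hydroxyethyl on the triple-bonded carbon. The steps among compound 1, compound 3 and compound 4 cannot be read, as each pair sits at the same limit: the limit of < 14 mL.min-1.g-1 in this assay, at which 3 of the 4 values shown sit.

Any true difference between the two alkynyl alcohol chain ends stays open, as does the place of compound 1, compound 3 and compound 4 relative to each other. Also open, going by these compounds, is whether an amine or a carboxylic acid in place of the hydroxyl, or a longer chain, on this triple-bonded carbon would stay at this limit.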